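Bromo for chloro at the limit of the growth assay

This account rests on a few compounds, and the source may have more. Where it says the series, first, only, none or still open, it means among the compounds named here.

In a functional assay on HL-60 cells (Homo sapiens) for antiproliferative activity, with a stated time of 72 h (on this read-out lower numbers stand for stronger inhibition of growth and higher numbers for weaker inhibition of growth), compound 2 (`C=C(CC)C(=O)c1ccc(OC(C)C(=O)O)cc1Cl`) gives > 60000 nM and that figure is a limit of the assay, not a number. Compound 1 (`C=C(C)C(=O)c1ccc(OC(C)C(=O)O)cc1Br`) reads > 60000 nM in this assay and this too is only a limit. Compound 2 therefore stands with the limit of > 60000 nM in this assay, at which 2 of the 2 values shown sit, and no graded value is available for either compound.

Compound 3 (`C=C(CC)C(=O)c1ccc(OC(C)C(=O)O)cc1Br`) departs from compound 2 in one place, with bromo in place of chloro on an aromatic carbon. Among the measured compounds shown here, the change is bromo in place of chloro on an aromatic carbon and no measured step between two compounds is available to size it. No shift beyond the usual scatter, in either direction, is expected in this assay for this exchange. That expectation rests only on the limit of compound 2 at > 60000 nM and so it is a weak guide. The step of a number no higher from compound 2 to compound 3 (the limit leaves the size open) is accordingly the estimated size of the change. For compound 3 the estimated value is 60000 nM with an expected range of 30000 nM to 120000 nM and a report of only a limit is the likeliest outcome.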

Compound 3, concentration for 50% growth inhibition: > 60000 nM
Compound 3 gave a limit, no number; the forecaster's own chance of this, stated with the estimate: 85%; the middle value sits exactly at the limit.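

No step can be read between compound 3 and either compound 2 or compound 1 in this assay, because all three stop at a limit of the assay: the limit of > 60000 nM in this assay, at which 3 of the 3 values shown sit.

The compounds shown leave open whether bromo in place of chloro, or methyl in place of hydrogen on the chain, changes growth inhibition at all.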